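Compound 2 to compound 3: unbound fraction in blood

The source may hold more compounds than are shown below. What is called first, only, known or untested is meant among the compounds shown, and "the series" means these compounds.

Compound 1 `CNC(=O)c1cc(C(=O)N[C@H]2CC[C@H](O)CC2)c([C@@H](C)c2cccc(Cl)c2)o1`: 0.1
Compound 2 `CNC(=O)c1cc(C(=O)N[C@H]2[C@@H]3C[C@@H](O)C[C@@H]32)c([C@@H](C)c2ccccc2)o1`: 0.2

In an ADME assay on blood (Canis lupus familiaris, strain Beagle) for protein binding, read by LC-MS, using equilibrium dialysis (a higher number here means a larger unbound share of the compound, a lower number a smaller unbound share), compound 2 gives 0.2, and this lies within the usual scatter of compound 1. The two compounds therefore cannot be told apart on these numbers. Compound 3 `CNC(=O)c1cc(C(=O)N[C@H]2CC[C@H](O)CC2)c([C@@H](C)c2ccccc2)o1` has not yet been measured. It differs from compound 2 in a single place, on an amide-type nitrogen: a group of 7 heavy atoms (6 carbon, 1 oxygen; one six-membered non-aromatic ring of carbon only) in place of a group of 7 heavy atoms (6 carbon, 1 oxygen; one three-membered non-aromatic ring of carbon only, one five-membered non-aromatic ring of carbon only), on an amide-type nitrogen. Within the data shown here, no measured pair shows this exchange on its own, so the data give no direct size for it. The nearest guide is compound 1, which also carries the 4-hydroxycyclohexyl group and gives 0.1. A small downward move is expected, with no change beyond the scatter, as an estimated 1.3-fold lower number from compound 2 to compound 3 (0.10 log units; within the scatter). In this assay, compound 3 is expected to give 0.16, with an estimated range of 0.08 to 0.3.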

Compound 3, unbound fraction: 0.26
Beside the measured number, compound 3's estimate is 1.6-fold (0.21 log units) below it; the range from low to high includes it.
By their numbers in this assay, from the lowest: compounds 1, 2 and 3 (each within the scatter of the next, the first and the last beyond it).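

On the amide-type nitrogen, 4-hydroxycyclohexyl in place of the group with a three-membered and a five-membered ring gives a 1.3-fold higher number from compound 2 to compound 3 (0.11 log units; within the scatter) in this assay, so this pair cannot be told apart, and the exchange has no visible size here. Compound 3 also supplies the first comparison that differs in one place on the other side of the molecule: hydrogen in place of chloro on an aromatic carbon gives a 2.6-fold higher number from compound 1 to compound 3 (0.41 log units; beyond the scatter), a modest step and the only one shown that lies beyond the scatter. Nothing at hand accounts for either step.

As far as these compounds go, it remains open whether the hydrogen-for-chloro step holds when the amide-type nitrogen carries the group of compound 2. From the compounds shown here alone, how a fluoro or methoxy group on that aromatic carbon, or an amine in place of the hydroxyl, would read in this assay also stays open.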